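Compound 3 to compound 4: extending the propoxy chain

This account rests on a few compounds, and the source may have more. Where it says the series, first, only, none or still open, it means among the compounds named here.

compound 1 `Cc1ccccc1-c1nc2cc[nH]cc-2n1` gives 2.2 mg/kg
compound 2 `COc1ccc(-c2nc3cc[nH]cc-3n2)cc1` gives 1.7 mg/kg
compound 3 `CCCOc1cc(OC)ccc1-c1nc2cc[nH]cc-2n1` gives 1.3 mg/kg

In a functional assay on the whole organism with Canis familiaris (Canis lupus familiaris) as the target (a higher number here means that more compound is needed for the effect, a lower number that less compound is needed), compound 3 at 1.3 mg/kg lies within the scatter of both compound 1 and compound 2, so the three cannot be separated on these numbers.

Compound 4 `COc1ccc(-c2nc3cc[nH]cc-3n2)c(OCC[S+](C)[O-])c1` differs from compound 3 by one change: a group of 3 heavy atoms (1 carbon, 1 oxygen, 1 sulfur; no ring) in place of one carbon atom, on a saturated chain carbon, two bonds along the chain from an oxygen on an aromatic ring in a group that carries no ring and sits on a saturated chain carbon, two bonds along the chain from an oxygen on an aromatic ring.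

Among the measured compounds shown here, only one measured step touches this chain. It is a 1.3-fold lower number from compound 2 to compound 3 (0.12 log units; within the scatter) for propoxy in place of hydrogen on an aromatic carbon, and it stays within the scatter. For the measured compounds named here, no measured compound carries sulfur or any other change on the chain, so the data give no direction for this step.

No shift beyond the scatter is therefore expected in this assay and the estimate stays close to the starting value. The step expected is a 1.1-fold lower number from compound 3 to compound 4 (0.03 log units; within the scatter) and it carries wide uncertainty. For compound 4 the estimated value is 1.2 mg/kg with an expected range from 0.5 mg/kg to 3 mg/kg as the working figure.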

Compound 4, dose for half-maximal effect: 5.2 mg/kg
Compound 4: middle estimate off by 4.3-fold (0.64 log units), on the low side; the whole stated range lies below it.
By their numbers in this assay, from the lowest: compounds 3, 2 and 1 (each within the scatter of the next); then compound 4.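

In this assay, among the compounds shown here, this chain carbon is the only place so far where a single change gives a step beyond the scatter: a 4.0-fold higher number from compound 3 to compound 4 (0.60 log units; beyond the scatter) when the group of 3 heavy atoms carrying sulfur and oxygen replaces one carbon atom on a saturated chain carbon, two bonds along the chain from an oxygen on an aromatic ring. The aromatic carbon that takes propoxy with a 1.3-fold lower number from compound 2 to compound 3 (0.12 log units; within the scatter) responds differently to the longer sulfur-bearing group, which gives a 3.1-fold higher number from compound 2 to compound 4 (0.49 log units; beyond the scatter) in the same assay, so a substituent here is not neutral whatever it carries. No measured property of the entering group is available to account for this, and the step stands as an observation only.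

The compounds shown leave open whether the shift follows the sulfur and its oxygen or any extension at this chain carbon, a question that a plain butoxy chain or a methoxyethoxy chain would address. They also leave open whether a thioether or a sulfone on the same chain, or an amine at its end, would behave like compound 4 or like compound 3.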